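Acetylation of the aminomethyl coumarin ester

The source may report more compounds than this note shows. Statements on the series, on what has been measured and on what is new or still open speak of the compounds shown alone.

Compound 1 `O=C(Oc1ccccc1)c1cc2cc([N+](=O)[O-])ccc2oc1=O` gives 76.7% in a functional assay on HT-1080 cells (Homo sapiens), read by transwell migration, with a stated time of 24 h, tested at 1 uM; on this read-out higher numbers stand for a weaker effect at the one concentration tested and lower numbers for a stronger effect. Compound 2 `NCc1ccc2oc(=O)c(C(=O)Oc3ccccc3)cc2c1` gives 85.5% in this assay, and the change a number 8.8 percentage points higher from compound 1 to compound 2 (within the scatter) leaves the two within the scatter of each other. Compound 3 `CC(=O)NCc1ccc2oc(=O)c(C(=O)Oc3ccccc3)cc2c1` differs from compound 2 by acetyl in place of hydrogen on an amine nitrogen. Going by the values given here, no measured step touches the amine nitrogen; the single step known, from compound 1 to compound 2, was small, so nothing here points to a change beyond the scatter. Compound 3 is therefore expected at 84% (range 68% to 98%), a step of a number 1.5 percentage points lower from compound 2 to compound 3 (within the scatter).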

Compound 3, a percentage reported as activity, at one concentration (the size of the read-out at that concentration, not a potency): 63.5%
For compound 3 the middle estimate is 20.5 percentage points above the measured one; measured number below the stated range.
By their numbers in this assay, from the lowest: compound 3; then compounds 1 and 2 (each within the scatter of the next).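

Acetyl on the amine nitrogen moves the read-out in this assay by a clear margin, which the earlier change from nitro to aminomethyl did not: the result is a number 22 percentage points lower from compound 2 to compound 3 (beyond the scatter) and points to a stronger effect. Acetamidomethyl in place of nitro on the aromatic carbon also gives a number 13.2 percentage points lower from compound 1 to compound 3 (beyond the scatter) and so separates from the nitro compound as well. Nothing available bears on why the acetyl group has this effect. From the compounds shown here alone, whether a longer acyl chain, a benzoyl group or a methanesulfonyl group on the same nitrogen would go further remains open, as does whether a second substituent on that nitrogen would keep the step.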